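The source may report more compounds than this note shows. Statements on the series, on what has been measured and on what is new or still open speak of the compounds shown alone.

In an ADME assay on Huh-7 cells (Homo sapiens) for cytotoxicity (on this read-out higher numbers stand for lower toxicity in this test and lower numbers for higher toxicity in this test), compound 1 `O=C(NC(=S)N1CCc2c(OCCCCCOc3ccc(Cl)cc3)cccc21)c1ccc(Br)cc1` gives 29100 nM. Compound 2 `CC(C)(C)c1ccc(C(=O)NC(=S)N2CCc3c(OCCCCCOc4ccc(Cl)cc4)cccc32)cc1` carries a tert-butyl in place of a bromo group on an aromatic carbon, and in this assay there is an at least 1.7-fold higher number from compound 1 to compound 2 (0.23 log units; that floor lies within the scatter). For compound 2 the result is a limit rather than a number: > 50000 nM. Compound 2 thus stands at the limit of > 50000 nM in this assay, at which 1 of the 2 values shown sits. Compound 3 `CCCC(=O)NC(=S)N1CCc2c(OCCCCCOc3ccc(Cl)cc3)cccc21` differs from compound 2 by propyl in place of 4-(tert-butyl)phenyl on a carbonyl carbon. Among the compounds with values here, the only measured step, from compound 1 to compound 2, alters a substituent on the aromatic ring rather than exchanging that ring for a chain, so it offers little guidance for this change. Both measured compounds show weak toxicity, one at the limit and the other not far from it. Compound 3 is therefore expected to stay in that weakly toxic region, with a step estimated as an at least 1.2-fold lower number from compound 2 to compound 3 (0.09 log units; that floor lies within the scatter). Compound 3 is estimated at 40000 nM, likely between 15000 nM and 100000 nM, with a fair chance that only a limit is reported again.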

Compound 3, half-maximal cytotoxic concentration: > 50000 nM
Compound 3 ended at the assay's limit; the forecaster's own chance of this, stated with the estimate: 45%; at least 1.2-fold (0.09 log units) between middle value and limit.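

Compound 3 shows that an aromatic ring on this carbonyl carbon is not required for a weak effect in this assay: a propyl chain, with no ring and fewer heavy atoms than 4-(tert-butyl)phenyl, serves as well here. Compound 3 gives > 50000 nM, which is a limit of the assay and not a number. Propyl in place of 4-bromophenyl gives an at least 1.7-fold higher number from compound 1 to compound 3 (0.23 log units; that floor lies within the scatter), while the step between the two compounds at the limit cannot be read.

How far each of these compounds lies past that ceiling stays hidden, and the comparison among them is capped at one point: the limit of > 50000 nM in this assay, at which 2 of the 3 values shown sit. On these data alone, whether an amine, a carboxylic acid or a longer chain on this carbonyl carbon would bring the number down remains open.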